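A few compounds are considered here, and "the series" means these few. Any claim that something is new, unique, unknown or untested is made for them only; others in the source may bear on it.

Series notes. The shared core carries a varied aryl group: compound 1 `c1ccc2c(-c3cn4ccnc4c(-c4ccc5ncn(C6CCCCC6)c5c4)n3)cccc2c1` bears naphthalen-1-yl, compound 2 `CC(=O)c1ccc(-c2cn3ccnc3c(-c3ccc4ncn(C5CCCCC5)c4c3)n2)cc1` bears 4-acetylphenyl, and compound 3 `Clc1ccc(-c2cn3ccnc3c(-c3ccc4ncn(C5CCCCC5)c4c3)n2)cc1` bears 4-chlorophenyl. In a functional assay on UO-31 cells (Homo sapiens) for inhibition, read by sulforhodamine B assay, with a stated time of 48 h, tested at 10 uM (on this read-out higher numbers stand for more inhibition at the one concentration tested (going by the name of the read-out) and lower numbers for less inhibition), compound 1 gives 23% and compound 2 gives 23.1%; the step of a number 0.1 percentage points higher from compound 1 to compound 2 (within the scatter) lies within the scatter. In this assay compound 3 gives 36.1%, the highest of the three numbers: the step of a number 13.1 percentage points higher from compound 1 to compound 3 (beyond the scatter) and the step of a number 13 percentage points higher from compound 2 to compound 3 (beyond the scatter) are both beyond the scatter, so compound 3 stands apart from the other two.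

Compound 4 `c1csc(-c2cn3ccnc3c(-c3ccc4ncn(C5CCCCC5)c4c3)n2)c1` has not been measured in this assay. Its change from compound 3 is thiophen-2-yl in place of 4-chlorophenyl on an aromatic carbon. Going by the values given here, no measured step exchanges a six-membered carbon ring for a five-membered ring with a hetero atom, so the measured steps bear on it only indirectly. The step of a number 13 percentage points higher from compound 2 to compound 3 (beyond the scatter) and the step of a number 13.1 percentage points higher from compound 1 to compound 3 (beyond the scatter) show that the group at this position moves the read-out by modest amounts, and compound 3 alone sits at the high end. The step of a number 10.1 percentage points lower from compound 3 to compound 4 (beyond the scatter) is therefore expected to run downward, toward the level of compounds 1 and 2, though a result within the scatter is possible. Compound 4 is estimated at 26%, with a range from 12% to 42%.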

Compound 4, a percentage reported as inhibition, at one concentration (the size of the read-out at that concentration, not a potency): 10.9%
Compound 4: the middle estimate sits 15.1 percentage points above what was measured; the measured number lies below the stated range.
By their numbers in this assay, from the lowest: compound 4; then compounds 1 and 2 (each within the scatter of the next); then compound 3.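

In this assay compound 4 gives the lowest number of the series, and all three of its steps are beyond the scatter: a number 25.2 percentage points lower from compound 3 to compound 4 (beyond the scatter), a number 12.2 percentage points lower from compound 2 to compound 4 (beyond the scatter) and a number 12.1 percentage points lower from compound 1 to compound 4 (beyond the scatter). The earlier compounds shown here showed this position moving the read-out only upward from the level shared by compounds 1 and 2, whereas thiophen-2-yl shows that it can also fall below that level, so the aryl groups now spread to both sides of that pair. Nothing at hand accounts for these differences.

Going by these compounds, it remains open whether the low number belongs to thiophen-2-yl itself or to five-membered aromatic rings with a hetero atom more widely, a question that thiophen-3-yl, furan-2-yl or thiazol-2-yl at the same place would address. On these data alone, it is equally open whether the higher number of compound 3 depends on its chloro group, which plain phenyl, 4-fluorophenyl or a phenyl ring carrying an amine or a carboxylic acid could test.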